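Sulfonamide series: replacing the benzylic trifluoromethyl by hydrogen

The compounds below may be only part of what the source reports. "The series", "measured", "known", "first", "only" and "open" are said of these compounds alone.

In an assay on cells for inhibition of sodium channel protein type 3 subunit alpha (Homo sapiens), read by electrophysiology (on this read-out higher numbers stand for weaker inhibition and lower numbers for stronger inhibition), compound 1 `O=C(NCc1ccc(C(F)(F)F)cc1)c1ccc(S(=O)(=O)Nc2nccs2)cc1` gives 147 nM. Compound 2 `O=S(=O)(NCc1ccc(C(F)(F)F)cc1)c1ccc(S(=O)(=O)Nc2nccs2)cc1`, the sulfonamide-linked counterpart, gives 160 nM in this assay. Compound 1 thus holds the lowest of the two numbers on hand, but its gap to compound 2 lies within the scatter, so the two values show no difference between the amide and the sulfonamide link. Compound 3 `O=C(NCc1ccccc1)c1ccc(S(=O)(=O)Nc2nccs2)cc1` is not yet measured. It differs from compound 1 by hydrogen in place of trifluoromethyl on an aromatic carbon. Within the data shown here, no step between two measured compounds shows what this change does: both measured compounds carry the same trifluoromethyl group and differ only on the linker side. For compound 3 a moderate step toward a higher number, beyond the scatter, is expected, a 2.7-fold higher number from compound 1 to compound 3 (0.43 log units; beyond the scatter). Compound 3 is therefore estimated at 400 nM in this assay, with a range from 150 nM to 1200 nM.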

Compound 3, half-maximal inhibitory concentration: 4450 nM
Beside the measured number, compound 3's estimate is 11-fold (1.05 log units) below it; measured number above the stated range.
By their numbers in this assay, from the lowest: compounds 1 and 2 (each within the scatter of the next); then compound 3.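

In this assay, among these compounds, hydrogen in place of trifluoromethyl on the aromatic carbon gives a 30-fold higher number from compound 1 to compound 3 (1.48 log units; beyond the scatter) and so provides the first reading at this place, as compound 1 and compound 2 carry the same trifluoromethyl group and differ only in the linker. The position is therefore far from indifferent in the amide series: the change removes 4 heavy atoms, with no hydrogen-bond donor, hydrogen-bond acceptor or net charge among them, and the low number of compound 1 is lost to a large degree. Nothing on hand shows which feature of the trifluoromethyl group accounts for this step.

Open, on these data alone, is whether a smaller or different group at this place, such as fluorine, chlorine, methyl, methoxy or nitrile, would keep the number near that of compound 1 or fall toward that of compound 3. Also open, as far as these compounds go, is whether hydrogen in place of trifluoromethyl would cost as much with the sulfonamide link of compound 2, and whether the same group would matter as much on another carbon of the ring.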